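A few compounds are considered here, and "the series" means these few. Any claim that something is new, unique, unknown or untested is made for them only; others in the source may bear on it.

Series notes. Three hydroxamic acids sharing one core have been run in a functional assay on SK-OV-3 cells (Homo sapiens) for cytotoxicity (a lower number here means a stronger inhibitor, a higher number a weaker inhibitor), so far. Compound 1 `O=C(CCCCCCc1nc2ccc(-c3cccc(F)c3)cc2[nH]1)NO` gives 1500 nM. Compound 2 `O=C(CCCCCCc1nc2ccc(-c3ccccc3F)cc2[nH]1)NO` gives 7400 nM, and compound 3 `CN(C)c1ccc(-c2ccc3nc(CCCCCCC(=O)NO)[nH]c3c2)cc1` gives 6600 nM. Among these three numbers compound 3 stands second highest: its nearest neighbour is compound 2, within the scatter, and its furthest is compound 1, which sits a 4.4-fold higher number from compound 1 to compound 3 (0.64 log units; beyond the scatter). For the measured compounds named here, the other step into compound 3, a 1.1-fold lower number from compound 2 to compound 3 (0.05 log units; within the scatter), is within the scatter, while the only step not touching compound 3 is a 4.9-fold higher number from compound 1 to compound 2 (0.69 log units; beyond the scatter).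

Next in line is compound 4 `COc1ccc(-c2ccc3nc(CCCCCCC(=O)NO)[nH]c3c2)cc1`. Relative to compound 3 the change is methoxy in place of dimethylamino on an aromatic carbon; the dimethylamino leaves and the methoxy enters, on an aromatic carbon of a six-membered aromatic ring of carbon only, para to a large group. Going by the values given here, no measured step swaps these two groups directly. The steps that do bear on it are the two that alter the substituent on the same pendant ring: a 4.4-fold higher number from compound 1 to compound 3 (0.64 log units; beyond the scatter) and a 1.1-fold lower number from compound 2 to compound 3 (0.05 log units; within the scatter), one modest and one within the scatter. A change of at most modest size is therefore expected in this assay, with no firm direction. The estimate for compound 4 is 6000 nM, ranging from 2500 nM to 15000 nM, which is expected to mean a 1.1-fold lower number from compound 3 to compound 4 (0.04 log units; within the scatter).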

Compound 4, half-maximal inhibitory concentration: 3100 nM
The estimate for compound 4 lay 1.9-fold (0.29 log units) above the measured number, within the range that was stated.
By their numbers in this assay, from the lowest: compound 1; then compound 4; then compounds 3 and 2 (each within the scatter of the next).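

Within this assay, the step of a 2.1-fold lower number from compound 3 to compound 4 (0.33 log units; beyond the scatter) is the first direct exchange at this place, on an aromatic carbon para to a large group, and it shows that methoxy and dimethylamino can be told apart there, though only by a modest step. Compound 4 also fills the gap in the series, with a 2.4-fold lower number from compound 2 to compound 4 (0.38 log units; beyond the scatter) and a 2.1-fold higher number from compound 1 to compound 4 (0.32 log units; beyond the scatter) both modest and beyond the scatter, so compound 1 remains the strongest of the four while the range no longer consists of one low value and two values within the scatter of each other. No measurement bearing on the reason for the difference between methoxy and dimethylamino is available in the material at hand.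

From the compounds shown here alone, it remains open how an unsubstituted phenyl would compare, which would give the substituted pendant rings a common reference. A hydroxy group, a primary amine or a carboxylic acid at the same place would test whether the modest spread among the four compounds holds for groups of other kinds.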